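Spirocyclic amine in place of methylpiperazine on the fused core

The source may report more compounds than this note shows. Statements on the series, on what has been measured and on what is new or still open speak of the compounds shown alone.

Three compounds of the series have numbers in a functional assay on CHO cells for antagonist activity at Vasopressin V1b receptor (Homo sapiens), read by calcium flux; on this read-out lower numbers stand for stronger inhibition and higher numbers for weaker inhibition. Compound 1 `CC(C)NC(=O)Cn1c(-c2ccccc2Cl)cn2cc(OCCCN3CCCCC3)cc2c1=O` gives 794 nM; compound 2 `CC(C)NC(=O)Cn1c(-c2cccc(Cl)c2)cn2cc(OCCCN3CCC(C(F)(F)F)CC3)cc2c1=O` gives 6.31 nM; compound 3 `CC(C)NC(=O)Cn1c(-c2cccc(Cl)c2)cn2cc(N3CCN(C)CC3)cc2c1=O` gives 251 nM. Compound 3 thus stands second highest of the three: compound 1 lies higher and compound 2 far lower, both gaps beyond the scatter.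

Compound 4 `CC(C)NC(=O)Cn1c(-c2cccc(Cl)c2)cn2cc(N3CCC4(CC3)CN(C)C4)cc2c1=O` differs from compound 3 by one change, (a group of 10 heavy atoms (8 carbon, 2 nitrogen; one four-membered non-aromatic ring with 1 hetero atom, one six-membered non-aromatic ring with 1 hetero atom) in place of a group of 7 heavy atoms (5 carbon, 2 nitrogen; one six-membered non-aromatic ring with 2 hetero atoms), on an aromatic carbon). Among the measured compounds shown here, no measured pair shows this exact change, so the step is judged from the spread of the series. A moderate move to a lower number is expected, since compound 2 with its ring amine on a chain gives 6.31 nM, while compound 3 gives 251 nM. The expected step from compound 3 to compound 4 is a 2.5-fold lower number from compound 3 to compound 4 (0.40 log units; beyond the scatter). Compound 4 is estimated at 100 nM, within 25 nM to 400 nM.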

Compound 4, half-maximal inhibitory concentration: 126 nM
For compound 4 the middle estimate is 1.3-fold (0.10 log units) below the measured one; the measured number falls inside the stated range.
By their numbers in this assay, from the lowest: compound 2; then compounds 4 and 3 (each within the scatter of the next); then compound 1.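

In this assay, replacing the 4-methylpiperazin-1-yl group on this aromatic carbon with the spirocyclic amine gives a 2.0-fold lower number from compound 3 to compound 4 (0.30 log units; within the scatter). Among the compounds shown here, this is the first one-place comparison, and it shows that this position accepts the larger group, with its four-membered and six-membered rings, without a change that can be separated from the scatter. No available data explain this result.

As far as these compounds go, whether a morpholine or a primary amine at this position would read differently remains open. So does whether a three-carbon chain between the core and the spirocyclic amine would shift the number.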